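A few compounds are considered here, and "the series" means these few. Any claim that something is new, unique, unknown or untested is made for them only; others in the source may bear on it.

Compound 2 `Cc1ccc(-c2c3ccc4ccccc4c3nc3c2c(C)nc2c4ccccc4ccc32)cc1` gives 192 ug/mL in a functional assay, with a stated time of 90 s (on this read-out lower numbers stand for stronger inhibition and higher numbers for weaker inhibition), the highest of the two numbers in hand. Compound 1 `Cc1nc2c3ccccc3ccc2c2nc3c(ccc4ccccc43)c(-c3ccccc3Cl)c12` gives 170 ug/mL, and the step of a 1.1-fold higher number from compound 1 to compound 2 (0.05 log units; within the scatter) lies within the scatter. Compound 3 `Cc1nc2c3ccccc3ccc2c2nc3c(ccc4ccccc43)c(-c3cccc4ccccc34)c12` differs from compound 2 by naphthalen-1-yl in place of 4-methylphenyl on an aromatic carbon. Going by the values given here, the one measured step that bears on this change, a 1.1-fold higher number from compound 1 to compound 2 (0.05 log units; within the scatter), is also an exchange of one aromatic group for another at the same place on the shared core and produced no shift beyond the scatter, so no step beyond the scatter is expected here either. Compound 3 is therefore expected to give about 190 ug/mL, with a range of 100 ug/mL to 360 ug/mL, a step of a 1.0-fold lower number from compound 2 to compound 3 (0.00 log units; within the scatter).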

Compound 3, half-maximal inhibitory concentration: 179 ug/mL
For compound 3 the middle estimate is 1.1-fold (0.03 log units) above the measured one; low and high end bracket the measured number.
By their numbers in this assay, from the lowest: compounds 1, 3 and 2 (each within the scatter of the next).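

In this assay naphthalen-1-yl brings a second six-membered aromatic ring to the aromatic carbon opposite the ring nitrogen, yet neither step leaves the scatter: a 1.1-fold lower number from compound 2 to compound 3 (0.03 log units; within the scatter) and a 1.1-fold higher number from compound 1 to compound 3 (0.02 log units; within the scatter). This position thus accommodates a two-ring carbon aromatic group as well as 4-methylphenyl and 2-chlorophenyl, without a separation among the three compounds. Nothing available explains this insensitivity. Open, on these data alone, is whether an amine, a carboxylic acid or a longer chain at this carbon would move the number beyond the scatter.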